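The source may hold more compounds than are shown below. What is called first, only, known or untested is meant among the compounds shown, and "the series" means these compounds.

Three compounds have been measured:

compound 1, `COc1ccc(F)cc1CNCCCNc1ccnc2cc(Cc3ccc(C#N)cc3)ccc12`, giving 9.47
compound 2, `c1ccc(CCc2ccc3c(NCCCNCc4ccco4)ccnc3c2)cc1`, giving 9.47
compound 3, `COc1cccc(CNCCCNc2ccnc3cc(Cc4cc(C)cc(C)c4)ccc23)c1O`, giving 9.47

All three were examined in a physicochemical assay for acid dissociation. On the numbers shown, compound 2 is level with compound 1 and compound 3 at the digits printed: the nearest of the two, compound 1, shows no change at those digits, and the furthest, compound 3, shows none either, so all three sit within the scatter of one another. Compound 2 therefore stands neither high nor low among them; the three values read as a single level.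

The next compound, compound 4, `c1coc(CNCCCNc2ccnc3cc(CC4CCCCC4)ccc23)c1`, has not yet been measured in this assay. It differs from compound 2 in one place: cyclohexyl in place of benzyl on a saturated chain carbon bound to an aromatic carbon. For the measured compounds named here, no step between measured compounds is available to calibrate this change, so the expectation rests on the three values alone. Since compounds 1 to 3 carry quite different groups in that region yet share one value, the step of no change at the digits printed from compound 2 to compound 4 (within the scatter) is expected to be no larger than the scatter, in no fixed direction. For compound 4 the estimate in this assay is 9.47, with a range from 9.17 to 9.77.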

Compound 4, acid dissociation constant: 9.47
For compound 4 middle estimate and measured number coincide at the digits printed; low and high end bracket the measured number.
By their numbers in this assay, from the lowest: compounds 1, 2, 3 and 4 (each within the scatter of the next).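

In this assay, for the compounds shown here, cyclohexyl in place of benzyl gives no change at the digits printed from compound 2 to compound 4 (within the scatter), and this is the first step here in which the two compounds differ in only one place, so the comparison is a direct one. It shows that, on a saturated chain carbon bound to an aromatic carbon, a six-membered aromatic ring of carbon only can be exchanged for a six-membered non-aromatic ring of carbon only without moving this read-out beyond the usual scatter. Nothing available explains this result, so it stands as an observation about this one pair.

On these data alone, whether the number would hold with an amine, a carboxylic acid or a longer chain at this position remains open, since both groups compared here are built of carbon alone and have no hydrogen-bond donors or acceptors. The compounds shown also offer no single-place step elsewhere in the molecule, so how this read-out responds to changes in other parts of the structure cannot yet be said.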